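The compounds below may be only part of what the source reports. "The series", "measured", "known", "first", "only" and "open" are said of these compounds alone.

Of the compounds shown here, two from this study have been measured in a functional assay on OVCAR-5 cells (Homo sapiens) for cytotoxicity, read by sulforhodamine B assay, with a stated time of 48 h, tested at 0.01 uM; a higher number here means a weaker effect of the compound at the concentration tested, a lower number a stronger effect. Compound 1 `COc1ccc(-c2cc(/C=C/C(=O)c3ccc(N)cc3)[nH]n2)cc1` carries a single methoxy group on one outer ring, and in this assay compound 1 gives 99%. Compound 2 `COc1cc(-c2cc(/C=C/C(=O)c3ccc(N)cc3)[nH]n2)cc(OC)c1OC` carries three methoxy groups on that ring, and in this assay compound 2 gives 90%. Compound 2's number differs from compound 1's by an amount within the usual scatter of repeated measurements, so the two compounds cannot be told apart on these data. Compound 3 `COc1ccc(-c2cc(/C=C/C(=O)c3ccc(N)cc3)[nH]n2)cc1OC` has not yet been measured; it differs from compound 2 in one place: hydrogen in place of methoxy on an aromatic carbon. Going by the values given here, no step between measured compounds is known, and the two numbers give no sign that adding or removing methoxy groups shifts the read-out, so no step beyond the scatter is expected in either direction, the expected step being a number 4 percentage points higher from compound 2 to compound 3 (within the scatter). Compound 3 is therefore expected to give 94%, within a range from 80% to 102%.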

Compound 3, a percentage reported as activity, at one concentration (the size of the read-out at that concentration, not a potency): 91%
Beside the measured number, compound 3's estimate is 3 percentage points above it; the measured number falls inside the stated range.
By their numbers in this assay, from the lowest: compounds 2, 3 and 1 (each within the scatter of the next).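

Two single changes on the methoxy-bearing ring can now be read directly in this assay. Hydrogen in place of the methoxy group on this aromatic carbon, ortho to a methoxy group and meta to a large group, gives a number 1 percentage points higher from compound 2 to compound 3 (within the scatter) on this read-out, so this methoxy group shows no effect that can be separated from the scatter at the tested concentration. A methoxy group in place of hydrogen on an aromatic carbon gives a number 8 percentage points lower from compound 1 to compound 3 (within the scatter) and likewise shows no measurable effect, while no measurement here offers an explanation for either result.

The compounds shown leave open whether a hydroxyl group, a fluorine atom or a longer chain such as ethoxy on this carbon would move the read-out beyond the scatter. They also leave open whether changing the amine elsewhere in the shared core would do so.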